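Carbamate-side variation in a cytotoxicity series

The source may hold more compounds than are shown below. What is called first, only, known or untested is meant among the compounds shown, and "the series" means these compounds.

Measured compounds:
compound 1 `CCCCC1CCC(OC(=O)N[C@@H](CC(C)C)C(=O)N[C@H](C=O)C[C@@H]2CCNC2=O)CC1`, in a toxicity assay on L929 cells (Mus musculus) for cytotoxicity (on this read-out higher numbers stand for lower toxicity in this test and lower numbers for higher toxicity in this test), compound 1 gives 63300 nM
compound 2 `CC(C)C[C@H](NC(=O)OCC1CCC(F)(F)CC1)C(=O)N[C@H](C=O)C[C@@H]1CCNC1=O`

In this assay compound 2 gives > 100000 nM, which is a limit of the assay and not a number. Compound 2 therefore stands only as a limit, marked by the limit of > 100000 nM in this assay, at which 1 of the 2 values shown sits. Among the compounds with values here, the one measured step, an at least 1.5-fold higher number from compound 1 to compound 2 (0.19 log units; that floor lies within the scatter), exchanged the group on an oxygen next to a carbonyl group; its floor lies within the scatter, so no real direction is established.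

Compound 3 `CC(C)C[C@H](NC(=O)OC1CCCCC1)C(=O)N[C@H](C=O)C[C@@H]1CCNC1=O` is not yet measured. It differs from compound 2 by cyclohexyl in place of (4,4-difluorocyclohexyl)methyl on an oxygen next to a carbonyl group. Within the data shown here, the only step that bears on this position is an at least 1.5-fold higher number from compound 1 to compound 2 (0.19 log units; that floor lies within the scatter), and it is small. No change beyond the scatter is expected; the estimate is an at least 1.2-fold lower number from compound 2 to compound 3 (0.09 log units; that floor lies within the scatter). Compound 3 is expected at 80000 nM, between 35000 nM and 180000 nM, with a fair chance that only a limit is reported.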

Compound 3, half-maximal cytotoxic concentration: > 100000 nM
Compound 3 ended at the assay's limit (the forecaster's own chance of this, stated with the estimate: 40%); at least 1.2-fold (0.09 log units) between middle value and limit.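

The step between compound 2 and compound 3 cannot be read, as both values are limits of the assay, so cyclohexyl and (4,4-difluorocyclohexyl)methyl on this oxygen cannot be ordered in this assay. Hydrogen in place of butyl on a saturated ring carbon gives an at least 1.5-fold higher number from compound 1 to compound 3 (0.19 log units; that floor lies within the scatter), so this change also establishes no real direction. Two different groups on this oxygen now share the same limit: the limit of > 100000 nM in this assay, at which 2 of the 3 values shown sit.

Open, on these data alone, is whether a chain longer than butyl on the ring, or an amine or a carboxylic acid there, would move the read-out in this assay beyond the scatter. Also open, as far as these compounds go, is where compound 2 and compound 3 truly stand relative to each other.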